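Swapping halogens for methyls on the aryl amine

A few compounds are considered here, and "the series" means these few. Any claim that something is new, unique, unknown or untested is made for them only; others in the source may bear on it.

Three compounds share one core and differ only in the substituted phenyl ring carried on a nitrogen attached to an aromatic carbon. Compound 1 `CCCN(Cc1sc(Nc2c(C)cc(Cl)cc2Cl)nc1C(F)(F)F)CC1CC1` gives 16 nM in an assay for displacement of a labelled ligand from corticotropin-releasing factor receptor 1 (Homo sapiens); a higher number here means a weaker inhibitor, a lower number a stronger inhibitor. Compound 2 `CCCN(Cc1sc(Nc2c(C)cc(C)cc2Cl)nc1C(F)(F)F)CC1CC1` gives 23 nM, and compound 3 `CCCN(Cc1sc(Nc2c(Br)cc(C)cc2Br)nc1C(F)(F)F)CC1CC1` gives 28 nM. Compound 3 has the highest of the three numbers, but it stands close to the others: a 1.8-fold higher number from compound 1 to compound 3 (0.24 log units; within the scatter) and a 1.2-fold higher number from compound 2 to compound 3 (0.09 log units; within the scatter), so nothing separates it from compound 1 or compound 2 beyond the scatter.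

Compound 4 `CCCN(Cc1sc(Nc2c(C)cc(C)cc2C)nc1C(F)(F)F)CC1CC1` continues the same theme. The change is 2,4,6-trimethylphenyl in place of 2,6-dibromo-4-methylphenyl on a nitrogen on an aromatic ring: every halogen on that ring is now a methyl.

The steps already measured all concern halogen-for-methyl or halogen-for-halogen exchanges on this ring. a 1.4-fold higher number from compound 1 to compound 2 (0.16 log units; within the scatter) replaced a single chloro with a methyl. a 1.8-fold higher number from compound 1 to compound 3 (0.24 log units; within the scatter) and a 1.2-fold higher number from compound 2 to compound 3 (0.09 log units; within the scatter) rearranged the mix of chloro, bromo and methyl groups. None moved this assay beyond the scatter. The expected step of a 1.3-fold lower number from compound 3 to compound 4 (0.10 log units; within the scatter) is therefore small, with no direction that can be trusted. Compound 4 is estimated at 22 nM in this assay, with a likely range from 8 nM to 60 nM.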

Compound 4, inhibition constant: 60 nM
Beside the measured number, compound 4's estimate is 2.7-fold (0.44 log units) below it; low and high end bracket the measured number.
By their numbers in this assay, from the lowest: compounds 1, 2 and 3 (each within the scatter of the next); then compound 4.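

For the compounds shown here, with no halogen left on the ring, this assay moves beyond the scatter for the first time in this set, as a 2.1-fold higher number from compound 3 to compound 4 (0.33 log units; beyond the scatter) shows. The gap is also beyond the scatter against the other two compounds, with a 2.6-fold higher number from compound 2 to compound 4 (0.42 log units; beyond the scatter) for the exchange of the one remaining chloro and a 3.8-fold higher number from compound 1 to compound 4 (0.57 log units; beyond the scatter) for the exchange of both chloro groups, so among these four compounds the 2,4,6-trimethylphenyl ring alone stands apart, and compound 4 is the weakest, while the three rings that keep at least one halogen stay within the scatter of their neighbours. Why the loss of the last halogen should matter when earlier swaps of chloro for methyl did not is something no data here can explain.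

The compounds shown leave open whether this ring needs a halogen as such or whether another group in its place, such as a methoxy or a nitrile, would return the number to the range of compounds 1 to 3. They also leave open how a ring bearing only halogens, such as 2,4,6-trichlorophenyl, would compare.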